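The source may report more compounds than this note shows. Statements on the series, on what has been measured and on what is new or still open speak of the compounds shown alone.

Within the data shown here, only two compounds have been measured so far in a physicochemical assay for lipophilicity; a lower number here means a more polar compound, a higher number a more lipophilic compound. Compound 1 (`CCCC(CCC)C(=O)OCC1(CO)C/C(=C/c2ccncc2)C(=O)O1`) gives 2.9, and compound 2 (`CN(C)c1ccc(C(=O)OCC2(CO)C/C(=C\c3ccccn3)C(=O)O2)cc1`) gives 2.07. Compound 2 therefore holds the lower of the two numbers, and its gap to compound 1 lies beyond the usual scatter.

Compound 3 (`CN(C)c1ccc(C(=O)OCC2(CO)C/C(=C\c3ccncc3)C(=O)O2)cc1`) has not yet been measured in this assay. It departs from compound 2 in one place: pyridin-4-yl in place of pyridin-2-yl on a double-bonded chain carbon bound to a double-bonded ring carbon. The two compounds have the same atoms, joined differently. Among the measured compounds shown here, no measured pair differing in one place is available, so the data offer no direct guide to the size of this change. Compound 2 differs from compound 1 in more than one place, so the value of compound 1, 2.9, cannot be read as the effect of this exchange.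

The expected step is small and slightly downward, a number 0.12 log units lower from compound 2 to compound 3 (within the scatter), and it is not expected to go beyond the scatter. For compound 3 the estimated value is 1.95, with an expected range from 1.6 to 2.3.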

Compound 3, partition coefficient: 2.07
Estimate against measurement, compound 3: 0.12 log units below, within the range that was stated.
By their numbers in this assay, from the lowest: compounds 2 and 3 (each within the scatter of the next); then compound 1.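

In this assay, among these compounds, pyridin-4-yl in place of pyridin-2-yl on a double-bonded chain carbon bound to a double-bonded ring carbon gives no change at the digits printed from compound 2 to compound 3 (within the scatter), and this is the first step in the set that differs in one place. It shows that, with the rest of the structure held and the same atoms joined differently, this exchange at this position does not carry the number beyond the scatter, something the gap to compound 1 could not show, as compound 1 differs from compound 2 in more than one place. No measurement at hand bears on the reason for this result.

The compounds shown leave open whether pyridin-3-yl or a pyrimidine ring at the same position would also stay within the scatter of compound 2, as one exchange of this kind says nothing about the others. On these data alone, it also remains open whether the exchange between pyridin-2-yl and pyridin-4-yl would read the same with a carboxylic acid in place of the dimethylamino group.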